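Butoxy to butylamino on the shared core

A few compounds are considered here, and "the series" means these few. Any claim that something is new, unique, unknown or untested is made for them only; others in the source may bear on it.

Measured so far in an ADME assay on CCRF-HSB-2 cells (Homo sapiens) for cytotoxicity, with a stated time of 7 days (a lower number here means that less compound is tolerated, a higher number that more compound is tolerated), as follows
- compound 1 `CCCCCCCCOc1nc(N)nc2c1ncn2/C=C1/CC1(CO)CO` gives > 20000 nM (a limit)
- compound 2 `CCCCOc1nc(N)nc2c1ncn2/C=C1/CC1(CO)CO` gives > 20000 nM (a limit)

Compound 2 stands only at a limit, and the whole evidence is the limit of > 20000 nM in this assay, at which 2 of the 2 values shown sit, and nothing more. Compound 3 `CCCCNc1nc(N)nc2c1ncn2/C=C1/CC1(CO)CO` brings butylamino in place of butoxy on an aromatic carbon. Among the compounds with values here, the one measured step, a step that the two limits leave unreadable from compound 1 to compound 2, is a different change and gives no size to carry over. No step beyond the scatter is therefore expected in this assay and no direction is favoured. The expected step is a step that the limit leaves unreadable from compound 2 to compound 3 (an estimate set against a limit). For compound 3 the estimated value is 25000 nM (expected range 8000 nM to 60000 nM) and another limit is quite possible.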

Compound 3, half-maximal cytotoxic concentration: > 20000 nM
Compound 3 was reported as a limit; the forecaster's own chance of this, stated with the estimate: 70%; the middle value does not contradict the limit.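

In this assay compound 3 gives > 20000 nM, a limit, and its steps from compound 1 and compound 2 cannot be read. Going by these compounds, whether octyloxy, butoxy and butylamino on the shared core differ at all in this assay stays open.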